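The source may hold more compounds than are shown below. What is called first, only, known or untested is meant among the compounds shown, and "the series" means these compounds.

Measured in a functional assay on Bel-7402 cells (Homo sapiens) for antiproliferative activity, with a stated time of 72 h; on this read-out lower numbers stand for stronger inhibition and higher numbers for weaker inhibition:
- compound 1 `COc1cc(OC)c(C(=O)/C=C/c2ccccc2Cl)c(O)c1CN1CCCCC1`: 3100 nM
- compound 2 `COc1cc(O)c2c(=O)cc(-c3ccccc3Cl)oc2c1CN1CCCCC1`: 118000 nM

Compound 1 holds the lower of the two numbers in this assay, and the gap between it and compound 2, which gives 118000 nM, lies beyond the scatter. Next in line is compound 3 `CCN(CC)Cc1c(OC)cc(OC)c(C(=O)/C=C/c2ccccc2Cl)c1O`, not yet measured, which keeps the core of compound 1 and changes only the amine: diethylamino in place of piperidin-1-yl on a saturated chain carbon bound to an aromatic carbon. In words, diethylamino stands in place of piperidin-1-yl on a saturated chain carbon bound to an aromatic carbon.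

Among the compounds with values here, no measured pair isolates this change, so there is no direct precedent for its size. The expectation starts from compound 1 at 3100 nM and assumes no step beyond the scatter, with a slight lean towards a higher number. The expected change is a 1.3-fold higher number from compound 1 to compound 3 (0.11 log units; within the scatter), an estimate that stays within the scatter. In this assay the estimated value for compound 3 is 4000 nM, expected to fall between 1500 nM and 11000 nM.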

Compound 3, half-maximal inhibitory concentration: 6700 nM
Compound 3: the middle estimate sits 1.7-fold (0.22 log units) below what was measured, and the stated range covers the measured number.
By their numbers in this assay, from the lowest: compound 1; then compound 3; then compound 2.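

In this assay, within the data shown here, diethylamino in place of piperidin-1-yl on a saturated chain carbon bound to an aromatic carbon gives a 2.2-fold higher number from compound 1 to compound 3 (0.33 log units; beyond the scatter) and is the first direct read on the amine at this place. The step is modest, but it shows that the amine is not a silent part of the core of compound 1, and that an open diethylamino group, with no ring, still leaves compound 3 with a measurable number in this read-out while the piperidin-1-yl form holds the lower one. Nothing at hand bears on what lies behind the step.

This single pair cannot separate the loss of the ring from the change in the groups on nitrogen, so pyrrolidin-1-yl, morpholin-4-yl or dimethylamino on the same chain carbon remain the open comparisons for telling whether the ring itself matters or whether any similar amine would serve. Also open, from the compounds shown here alone, is whether diethylamino in place of piperidin-1-yl moves the number in the same direction and by a similar size on the core of compound 2.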